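Replacing a Pyridylmethyl Amine with a Trifluoropropyl Amine

The source may hold more compounds than are shown below. What is called first, only, known or untested is meant among the compounds shown, and "the series" means these compounds.

Compound 1 `Cc1csc2cc([C@H](C)Nc3ncnc(N)c3C#N)c(-c3cccc(CN4CCC(CN(C)Cc5ccccn5)CC4)c3)c(=O)n12` was measured in a physicochemical assay for lipophilicity (a lower number here means a more polar compound, a higher number a more lipophilic compound), and gave 2. Within the data shown here, compound 2 `Cc1csc2cc([C@H](C)Nc3ncnc(N)c3C#N)c(-c3cccc(CN(C)CCCN(C)Cc4ccc(Cl)cc4)c3)c(=O)n12` gives 3.2 in this assay, so compound 1 stands as the lower of the two numbers measured so far. Compound 3 `Cc1csc2cc([C@H](C)Nc3ncnc(N)c3C#N)c(-c3cccc(CN4CCC(N(C)CCC(F)(F)F)CC4)c3)c(=O)n12` has not yet been measured. It differs from compound 1 in one place: methyl(3,3,3-trifluoropropyl)amino in place of (methyl((pyridin-2-yl)methyl)amino)methyl on a saturated ring carbon. Among the measured compounds shown here, no measured pair shows this change directly. For compound 3 the estimate in this assay is 2.7, with a range from 2.1 to 3.3. The expected step, a number 0.70 log units higher from compound 1 to compound 3 (beyond the scatter), is a moderate rise beyond the usual scatter.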

Compound 3, distribution coefficient: 1.1
Beside the measured number, compound 3's estimate is 1.60 log units above it; the measured number lies below the stated range.
By their numbers in this assay, from the lowest: compound 3; then compound 1; then compound 2.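

At this saturated ring carbon, methyl(3,3,3-trifluoropropyl)amino in place of (methyl((pyridin-2-yl)methyl)amino)methyl gives a number 0.90 log units lower from compound 1 to compound 3 (beyond the scatter) in this assay. Among these compounds, this is the first measured pair differing in one place, and it shows that this swap, which brings in fluorine and removes the aromatic ring, lowers the number at this position. Nothing available explains the direction of this step. From the compounds shown here alone, the change alters several things at once, so the share of the fluorine atoms stays open. A plain methyl(propyl)amino group on the same ring carbon would separate that share from the loss of the aromatic ring.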